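This account rests on a few compounds, and the source may have more. Where it says the series, first, only, none or still open, it means among the compounds named here.

Compounds measured in an assay on isolated protein (strain albino) for antagonist activity at Voltage-dependent L-type calcium channel subunit alpha-1C (Cavia porcellus); on this read-out higher numbers stand for weaker inhibition and lower numbers for stronger inhibition:
- compound 1 `COCCOC(=O)C1=C(C)NC(C)=C(C(=O)OCCOC)C1c1cnc(SC)n1Nc1ccccc1` gives 17.9 nM
- compound 2 `CCOC(=O)C1=C(C)NC(C)=C(C(=O)OC)C1c1cnc(SC)n1Nc1ccccc1` gives 1.66 nM
- compound 3 `CCOC(=O)C1=C(C)NC(C)=C(C(=O)OC(C)C)C1c1cnc(SC)n1Nc1ccccc1` gives 3.22 nM

Compound 3 sits second highest of the three numbers; compound 2 lies within the scatter of it, while compound 1, which carries 2-methoxyethyl on both ester oxygens, gives a higher number beyond the scatter. Compound 4 `CCOC(=O)C1=C(C)NC(C)=C(C(=O)OCCOC)C1c1cnc(SC)n1Nc1ccccc1` is not yet measured; it differs from compound 3 by 2-methoxyethyl in place of isopropyl on an oxygen next to a carbonyl group. Within the data shown here, the one measured step at this position, a 1.9-fold higher number from compound 2 to compound 3 (0.29 log units; within the scatter), did not move this assay. Among the measured compounds shown here, no measured step isolates the 2-methoxyethyl change on its own, but compound 1 suggests this group tends toward higher numbers. A modestly higher number is therefore expected for compound 4, a 1.9-fold higher number from compound 3 to compound 4 (0.27 log units; within the scatter), giving an estimated 6 nM with a range of 2.5 nM to 15 nM.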

Compound 4, half-maximal inhibitory concentration: 2.91 nM
The estimate for compound 4 lay 2.1-fold (0.31 log units) above the measured number; the measured number falls inside the stated range.
By their numbers in this assay, from the lowest: compounds 2, 4 and 3 (each within the scatter of the next); then compound 1.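

In this assay, 2-methoxyethyl on this oxygen reads like the smaller groups: a 1.1-fold lower number from compound 3 to compound 4 (0.04 log units; within the scatter) and a 1.8-fold higher number from compound 2 to compound 4 (0.24 log units; within the scatter) leave methyl, isopropyl and 2-methoxyethyl indistinguishable. The high number of compound 1 therefore does not follow from one 2-methoxyethyl group alone, as a 6.2-fold lower number from compound 1 to compound 4 (0.79 log units; beyond the scatter) shows that the step beyond the scatter comes with the methoxy on the other ester chain. Nothing available explains this difference. As far as these compounds go, whether a longer chain or an amine at the end of this chain would also stay within the scatter remains open.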